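This account rests on a few compounds, and the source may have more. Where it says the series, first, only, none or still open, it means among the compounds named here.

Measured so far in a toxicity assay on Vero C1008 cells (Chlorocebus sabaeus) for cytotoxicity, read by MTT assay, with a stated time of 48 h; on this read-out lower numbers stand for higher toxicity in this test and higher numbers for lower toxicity in this test:
compound 1 `O=C(Nc1ccc([N+](=O)[O-])cc1)c1cc(Cl)ccc1O`: 2280 nM
compound 2 `O=C(Nc1ccc(C(F)(F)F)cc1)c1cc(Cl)ccc1O`: 1180 nM

Among the compounds with values here, with only these two numbers, compound 2 cannot be ranked against compound 1, because the one measured step is a 1.9-fold lower number from compound 1 to compound 2 (0.29 log units; within the scatter). Both compounds therefore sit in the same range.

The next compound, compound 3 `O=C(Nc1ccc(O)cc1)c1cc(Cl)ccc1O`, keeps the shared core and alters a single group: hydroxy in place of trifluoromethyl on an aromatic carbon. Here hydroxy takes the place of trifluoromethyl on an aromatic carbon, para to a large group.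

Within the data shown here, the only measured step that bears on this change is the earlier swap of nitro for trifluoromethyl on that same carbon, and it stayed within the scatter. That swap did not involve hydroxy, so it offers only weak guidance. The data give no firm direction, but a modest move towards higher numbers in this assay is expected, with real uncertainty on either side. The expected change is a 2.5-fold higher number from compound 2 to compound 3 (0.41 log units; beyond the scatter). For compound 3 the estimate is 3000 nM, with an expected range from 1000 nM to 10000 nM.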

Compound 3, half-maximal cytotoxic concentration: > 100000 nM
Compound 3 was reported as a limit (the forecaster's own chance of this, stated with the estimate: 5%); at least 33-fold (1.52 log units) between middle value and limit.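

Compound 3 is reported in this assay only as a limit and not as a number: the limit of > 100000 nM in this assay, at which 1 of the 3 values shown sits. Up to now this position, para to a large group, had shown only one step within the scatter, the swap of nitro for trifluoromethyl, so it could have seemed indifferent to the group it carries; hydroxy shows otherwise, with an at least 84-fold higher number from compound 2 to compound 3 (1.92 log units; beyond the scatter) and an at least 43-fold higher number from compound 1 to compound 3 (1.64 log units; beyond the scatter). On these data alone, since a higher number stands for lower toxicity in this test, this one change on an aromatic carbon takes the compound from the shared range of compounds 1 and 2 to far lower toxicity, and the full size of the move stays unknown.

Open, as far as these compounds go, is whether this large move belongs to hydroxy alone or would also appear with an amine or a methoxy group on the same carbon. The three compounds also cannot separate the hydrogen-bond donor and acceptor that enter with hydroxy from the drop in heavy atoms, since both arrive together in the same change.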